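The source may report more compounds than this note shows. Statements on the series, on what has been measured and on what is new or still open speak of the compounds shown alone.

Values in a functional assay on HEK293 cells (Homo sapiens) for cytotoxicity; a lower number here means that less compound is tolerated, a higher number that more compound is tolerated:
Compound 1 `COc1ccc([C@H]2CC(=O)N(Cc3cccc(C#N)c3)C2)cc1OC1CCCC1`: > 10000 nM
Compound 2 `COc1ccc([C@H]2CC(=O)N(C(C)=O)C2)cc1OC1CCCC1`: > 10000 nM
Compound 3 `COc1ccc([C@H]2CC(=O)N(c3ccccc3C)C2)cc1OC1CCCC1`: > 10000 nM

Each entry is a limit of the assay, not a number, so compound 3 has no exact place among the three.

Compound 4 `COc1ccc([C@H]2CC(=O)N(c3ccncc3)C2)cc1OC1CCCC1` carries pyridin-4-yl in place of 2-methylphenyl on an amide-type nitrogen in a ring. Two measured changes at that nitrogen bear on this: a step that the two limits leave unreadable from compound 1 to compound 3 and a step that the two limits leave unreadable from compound 2 to compound 3. Neither has a readable size, but compound 1, compound 2 and compound 3 share one result: the limit of > 10000 nM in this assay, at which 3 of the 3 values shown sit. On that basis, the expected change is a step that the limit leaves unreadable from compound 3 to compound 4, with nothing beyond the usual scatter. For compound 4 the estimated value is 15000 nM, with an expected range of 6000 nM to 40000 nM.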

Compound 4, half-maximal cytotoxic concentration: > 10000 nM
Compound 4 was reported as a limit (the forecaster's own chance of this, stated with the estimate: 85%); the middle value is on the limit's open side.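

In this assay compound 4 gives > 10000 nM as a limit of the assay. For the compounds shown here, no step among compound 1, compound 2, compound 3 and compound 4 can be read, because every result is such a limit: the limit of > 10000 nM in this assay, at which 4 of the 4 values shown sit. On these data alone, whether any group on the amide-type nitrogen changes how much compound is tolerated stays open.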